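The source may hold more compounds than are shown below. What is called first, only, known or untested is meant among the compounds shown, and "the series" means these compounds.

The series shares one core; compound 1 `Cc1ccc(C)c(-c2nc(CN3CCC(C(=O)NCCCN4C[C@H](C)C[C@H](C)C4)CC3)c(C)o2)c1` carries a 2,5-dimethylphenyl group on it. Among the compounds with values here, in an ADME assay on microsomes from liver (Rattus norvegicus) for metabolic stability, read by LC-MS, using NADPH, at 37 degrees C (a higher number here means that the compound lasts longer, a lower number that the compound disappears faster), compound 1 gives 0.5 h, the highest of the three numbers measured so far. Compound 3 `Cc1cccc(Cl)c1-c1nc(CN2CCC(C(=O)NCCCN3CCCC(C)C3)CC2)c(C)o1` gives 0.09 h, the nearest value, a gap that lies beyond the usual scatter. Compound 2 `Cc1ccccc1-c1nc(CN2CCC(C(=O)NCCCN3CCCC(CC(C)C)C3)CC2)c(C)o1` gives 0.0383 h, the furthest from compound 1, again beyond the scatter. Compound 4 `COc1cccc(C)c1-c1nc(CN2CCC(C(=O)NCCCN3C[C@H](C)C[C@H](C)C3)CC2)c(C)o1` has not yet been measured. It differs from compound 1 in one place: 2-methoxy-6-methylphenyl in place of 2,5-dimethylphenyl on an aromatic carbon. Within the data shown here, no pair of measured compounds shows this change, so the outlook rests on the three numbers alone. Because compound 1 stands at 0.5 h while the other two sit well lower, a half-life near or somewhat under that of compound 1 is expected for compound 4. The expected step of a 1.7-fold lower number from compound 1 to compound 4 (0.22 log units; within the scatter) is a modest decrease, likely within or at the edge of the scatter. Compound 4 is estimated at 0.3 h, with a range from 0.1 h to 0.9 h.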

Compound 4, half-life: 0.0767 h
Compound 4: middle estimate off by 3.9-fold (0.59 log units), on the high side; the measured number lies below the stated range.
By their numbers in this assay, from the lowest: compounds 2, 4 and 3 (each within the scatter of the next, the first and the last beyond it); then compound 1.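

In this assay, the aryl group on this aromatic carbon of the shared core proves to matter: putting 2-methoxy-6-methylphenyl in place of 2,5-dimethylphenyl, with the rest of the structure unchanged, gives a 6.5-fold lower number from compound 1 to compound 4 (0.81 log units; beyond the scatter) in half-life. Within the data shown here, the earlier compounds differed from one another in more than one place, so this is the first reading of a change at this position alone, and it shows that the half-life responds to this aryl group. Nothing measured here accounts for the loss.

The step replaces the whole aryl group, so the compounds shown do not separate the entry of the methoxy group from the different placing of the methyl group. Going by these compounds, how a hydroxyl group, a fluorine or an ethoxy group in place of that methoxy group would read in this assay also stays open.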